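Sulfonyl substituent exchange in the sulfonylbenzyl amide series

The compounds below may be only part of what the source reports. "The series", "measured", "known", "first", "only" and "open" are said of these compounds alone.

Compound 3, `O=C(NCc1ccc(S(=O)(=O)C2CCOCC2)cc1)N1Cc2ccncc2C1`, gives 35 nM in a functional assay on A2780 cells (Homo sapiens) for cytotoxicity, read by sulforhodamine B assay, with a stated time of 72 h; a lower number here means a stronger inhibitor, a higher number a weaker inhibitor. Among the three numbers in hand it stands second: compound 2, `O=C(NCc1ccc(S(=O)(=O)c2ccccc2)cc1)c1cc2cnccc2[nH]1`, gives 18 nM in this assay, a gap that lies within the scatter, while compound 1, `O=C(NCc1ccc(S(=O)(=O)c2ccccc2)cc1)NCc1cccnc1`, gives 610 nM in this assay, a gap well beyond it. Going by the values given here, the only step between compounds that differ in a single place is a 34-fold lower number from compound 1 to compound 2 (1.53 log units; beyond the scatter), and that change sits on the carbonyl carbon, not on the sulfonyl sulfur. Compound 4, `O=C(NCc1ccc(S(=O)(=O)N2CCC(N3CCCC3)CC2)cc1)N1Cc2ccncc2C1`, carries the change (4-(pyrrolidin-1-yl)piperidin-1-yl in place of oxan-4-yl on a sulfonyl sulfur). Among the compounds with values here, no measured step touches the group on the sulfonyl sulfur: compound 2 and compound 3 differ there, but they also differ on the carbonyl side, so their two values show only that both fall close together in this assay. With nothing in the series to set a direction for this exchange, the step expected in this assay is a 1.3-fold higher number from compound 3 to compound 4 (0.11 log units; within the scatter), which is taken as lying within the scatter. Compound 4 is therefore estimated at 45 nM in this assay, with a range from 15 nM to 150 nM.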

Compound 4, half-maximal inhibitory concentration: 5.6 nM
Estimate against measurement, compound 4: 8.0-fold (0.91 log units) above, outside the stated range (below it).
By their numbers in this assay, from the lowest: compound 4; then compounds 2 and 3 (each within the scatter of the next); then compound 1.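

Going by these compounds alone, the group on the sulfonyl sulfur is not a silent position in this assay: with the rest of the molecule held as in compound 3, the exchange alone gives a step beyond the scatter (a 6.3-fold lower number from compound 3 to compound 4 (0.80 log units; beyond the scatter)), which no earlier pair could show. Within the data shown here, this is the first measured step at this position, and it shows that the position tolerates a larger group, with 4-(pyrrolidin-1-yl)piperidin-1-yl (two non-aromatic rings) in place of oxan-4-yl (one non-aromatic ring) giving a lower number rather than a loss. Nothing at hand bears on why the number falls, and this single step cannot assign it to the added ring, the nitrogens or the loss of the oxygen.

On these data alone, whether the same exchange holds with a different group on the carbonyl carbon, such as that of compound 2, remains open. Also open, as far as these compounds go, is how much of the step depends on the pyrrolidine ring, which a plain piperidin-1-yl, a 4-(dimethylamino)piperidin-1-yl or a 4-carboxypiperidin-1-yl on the sulfonyl sulfur would help to separate.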